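Replacing methyl with chloro in compound 3

The compounds below may be only part of what the source reports. "The series", "measured", "known", "first", "only" and "open" are said of these compounds alone.

Among the compounds with values here, in an ADME assay on J774 cells (Mus musculus) for cytotoxicity (a lower number here means that less compound is needed, a higher number that more compound is needed for the effect), compound 3 `Cc1ccc2[nH]c(C)c(Br)c(=O)c2c1` gives 19600 nM, the only true number so far. Compound 1 `Cc1[nH]c2ccccc2c(=O)c1/C=C/c1cccc([N+](=O)[O-])c1` gives > 32600 nM, which is a limit. Compound 2 `COc1ccc2[nH]c(C)c(Br)c(=O)c2c1` gives > 37300 nM, which is also a limit. Compound 4 `Cc1[nH]c2ccc(Cl)cc2c(=O)c1Br` is still unmeasured, and it carries chloro in place of methyl on an aromatic carbon. Within the data shown here, the one measured step that bears on this is a different swap on an aromatic carbon, methyl in place of methoxy. With only an at least 1.9-fold lower number from compound 2 to compound 3 (0.27 log units; that floor lies within the scatter) to go on, no step beyond the scatter is expected in this assay. The estimated step is a 1.0-fold higher number from compound 3 to compound 4 (0.01 log units; within the scatter). Compound 4 is expected at 20000 nM, within an estimated range from 9000 nM to 40000 nM.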

Compound 4, half-maximal effective concentration: 21700 nM
For compound 4 the middle estimate is 1.1-fold (0.04 log units) below the measured one; the measured number falls inside the stated range.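

In this assay chloro in place of methyl on this aromatic carbon gives a 1.1-fold higher number from compound 3 to compound 4 (0.04 log units; within the scatter) and the two groups cannot be told apart here. Chloro in place of methoxy gives an at least 1.7-fold lower number from compound 2 to compound 4 (0.23 log units; that floor lies within the scatter) and this is only a floor. Compound 2 carries a limit, not a true number: the limit of > 37300 nM in this assay, at which 1 of the 4 values shown sits.

The compounds shown leave open whether another group on this carbon, such as an amine or a carboxylic acid, would give a step beyond the scatter. They also leave open how far compound 2 truly lies from compound 4.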